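Cytotoxicity of the shared core with varied six-position substituents

The compounds below may be only part of what the source reports. "The series", "measured", "known", "first", "only" and "open" are said of these compounds alone.

Measured so far in an ADME assay on BCBL1 cells (Homo sapiens) for cytotoxicity, with a stated time of 7 days; a lower number here means that less compound is tolerated, a higher number that more compound is tolerated:
compound 1 `CNc1nc(N)nc2c1ncn2/C=C1/CC1(CO)CO`: 67000 nM
compound 2 `CC(C)CSc1nc(N)nc2c1ncn2/C=C1/CC1(CO)CO`: > 20000 nM
compound 3 `CN(C)c1nc(N)nc2c1ncn2/C=C1/CC1(CO)CO`: > 20000 nM

For the measured compounds named here, compound 1 is the only compound of the set with a value reported as a number. For compound 2 the value > 20000 nM is a limit of the assay. For compound 3 the value > 20000 nM is likewise a limit. Accordingly a step that the limit leaves unreadable from compound 1 to compound 2 and a step that the limit leaves unreadable from compound 1 to compound 3 cannot be sized, nor can a step that the two limits leave unreadable from compound 2 to compound 3; both limits sit at the limit of > 20000 nM in this assay, at which 2 of the 3 values shown sit.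

Compound 4 `CCCSc1nc(N)nc2c1ncn2/C=C1/CC1(CO)CO` differs from compound 1 by propylsulfanyl in place of methylamino on an aromatic carbon. Of the measured steps, a step that the limit leaves unreadable from compound 1 to compound 2 is the closest analogue, since propylsulfanyl and isobutylsulfanyl both replace methylamino, but its size is unreadable; no step beyond the scatter is expected in this assay. Compound 4 is thus estimated at 60000 nM, expected between 20000 nM and 180000 nM, which would mean a 1.1-fold lower number from compound 1 to compound 4 (0.05 log units; within the scatter).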

Compound 4, half-maximal cytotoxic concentration: > 20000 nM
Compound 4: no number, only a limit (the forecaster's own chance of this, stated with the estimate: 50%); the middle value lies beyond the limit too.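

In this assay compound 4 gives > 20000 nM, which is a limit. No new step can be read between compound 4 and compound 1, compound 2 or compound 3: the limit of > 20000 nM in this assay, at which 3 of the 4 values shown sit.

The compounds shown leave open how compound 2, compound 3 and compound 4 rank against each other and how far each lies from compound 1.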